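The source may report more compounds than this note shows. Statements on the series, on what has been measured and on what is new or still open speak of the compounds shown alone.

Measured so far in a functional assay for inhibition of sodium/hydrogen exchanger (Oryctolagus cuniculus); a higher number here means a weaker inhibitor, a lower number a stronger inhibitor:
compound 1 `CS(=O)(=O)c1cc(C(=O)N=C(N)N)c(Cl)cc1Cl` gives 140 nM
compound 2 `CCc1cc(C)c(C(=O)N=C(N)N)cc1S(C)(=O)=O` gives 4.8 nM
compound 3 `Cc1ccc(-c2ccc(C(=O)N=C(N)N)cc2S(C)(=O)=O)cc1` gives 100 nM

Compound 2 has the lowest number of the three and is therefore the strongest inhibitor here; the next nearest, compound 3, and the furthest, compound 1, both sit beyond the scatter above it. Compound 4 `Cc1cc(-c2ccc(Cl)cc2Cl)c(S(C)(=O)=O)cc1C(=O)N=C(N)N` shares the core of compound 2, and the change is 2,4-dichlorophenyl in place of ethyl on an aromatic carbon. Among the compounds with values here, no measured pair shows this exact change, so the size of the step can only be guessed. The two weaker compounds, compound 1 and compound 3, differ from compound 2 in several places at once, so their numbers give no direct guide. Compound 4 is expected to lose potency, with a step of a 6.3-fold higher number from compound 2 to compound 4 (0.80 log units; beyond the scatter) in this assay. The estimate for compound 4 is 30 nM, within 8 nM to 150 nM.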

Compound 4, half-maximal inhibitory concentration: 42 nM
For compound 4 the middle estimate is 1.4-fold (0.15 log units) below the measured one; measured number inside the range.
By their numbers in this assay, from the lowest: compound 2; then compound 4; then compounds 3 and 1 (each within the scatter of the next).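

In this assay, putting 2,4-dichlorophenyl in place of ethyl, on the aromatic carbon ortho to the methylsulfonyl group, gives an 8.8-fold higher number from compound 2 to compound 4 (0.94 log units; beyond the scatter). So this position can carry an aromatic ring and still give inhibition, though the change costs potency beyond the scatter. No measurement here accounts for the size of this step.

From the compounds shown here alone, with only ethyl and 2,4-dichlorophenyl to compare at this carbon, the part played by the two chlorines stays open. So does how a plain phenyl ring, a propyl chain or an amine would behave there.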